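The source may hold more compounds than are shown below. What is called first, only, known or untested is meant among the compounds shown, and "the series" means these compounds.

Measured so far:
compound 1 `CNC(=O)c1cc(C(=O)NCCC2CCOCC2)cn(Cc2ccccc2)c1=O` — 3.6
compound 2 `CNC(=O)c1ccc(=O)n(Cc2cc(Br)ccc2F)c1` — 2.6
compound 3 `CNC(=O)c1cc(C(=O)NC2CC2)cn(Cc2cccc([C@@H](C)O)c2)c1=O` — 2.2

In a physicochemical assay for lipophilicity, at pH 7.4 (on this read-out higher numbers stand for higher lipophilicity and lower numbers for lower lipophilicity), compound 1 stands highest of the three numbers; compound 2 comes nearest, a full unit lower and beyond the scatter, and compound 3 lies furthest, lower still and also beyond the scatter. The unmeasured compound 4 `CNC(=O)c1cc(C(=O)NC(C)C)cn(Cc2ccccc2)c1=O` keeps the core of compound 1 and changes one place: isopropyl in place of 2-(oxan-4-yl)ethyl on an amide-type nitrogen. Among the compounds with values here, no pair of measured compounds traces this step, so its size is unknown from the data. Given the shift from a larger group bearing one hydrogen-bond acceptor to a small carbon-only group, a step downward is expected, a number 0.70 log units lower from compound 1 to compound 4 (beyond the scatter), beyond the scatter. Compound 4 is therefore estimated at 2.9, in a range from 2.4 to 3.4.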

Compound 4, distribution coefficient: 3.6
Beside the measured number, compound 4's estimate is 0.70 log units below it, and the stated range ends below it.
By their numbers in this assay, from the lowest: compound 3; then compound 2; then compounds 1 and 4 (each within the scatter of the next).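

In this assay, within the data shown here, isopropyl in place of 2-(oxan-4-yl)ethyl on the amide-type nitrogen gives no change at the digits printed from compound 1 to compound 4 (within the scatter) and is the first step that can be read at this position. For these two groups, the read-out does not separate a six-membered ring chain of 8 heavy atoms, including a hydrogen-bond acceptor, from 3 carbon atoms with no ring. Nothing available explains this result. The compounds shown leave open whether a longer alkyl chain, an amine or a carboxylic acid on this nitrogen would also leave the number in place.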